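The source may hold more compounds than are shown below. What is called first, only, known or untested is meant among the compounds shown, and "the series" means these compounds.

In a functional assay on A375P cells (Homo sapiens) for inhibition, read by MTT assay, with a stated time of 24 h (on this read-out lower numbers stand for stronger inhibition of growth and higher numbers for weaker inhibition of growth), compound 1 (`COc1ccc(Cn2ncc3c2NC(=O)CC(c2cccc(NC(=O)Nc4cccc(Cl)c4)c2)=N3)cc1`) gives 910 nM and compound 2 (`COc1ccc(Cn2ncc3c2NC(=O)CC(c2cccc(NC(=O)Nc4ccc(Cl)cc4)c2)=N3)cc1`) gives 640 nM on the same core. Compound 3 (`COc1ccc(Cn2ncc3c2NC(=O)CC(c2cccc(NC(=O)Nc4cc(Cl)cc(Cl)c4)c2)=N3)cc1`) gives 780 nM and stands within the scatter of both other compounds, so no order among the three can be read.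

Compound 4 (`COc1ccc(Cn2ncc3c2NC(=O)CC(c2cccc(NC(=O)Nc4ccc(Cl)c(Cl)c4)c2)=N3)cc1`) has 3,4-dichlorophenyl in place of 3,5-dichlorophenyl on an amide-type nitrogen, with the same atoms joined differently (3,4-dichlorophenyl in place of 3,5-dichlorophenyl on an amide-type nitrogen). Among the compounds with values here, no measured step covers this exact exchange. The nearest evidence is three small steps. There is a 1.4-fold lower number from compound 1 to compound 2 (0.15 log units; within the scatter) with 4-chlorophenyl in place of 3-chlorophenyl on an amide-type nitrogen, a 1.2-fold lower number from compound 1 to compound 3 (0.07 log units; within the scatter) with chloro in place of hydrogen on an aromatic carbon, and a 1.2-fold higher number from compound 2 to compound 3 (0.09 log units; within the scatter) with 3,5-dichlorophenyl in place of 4-chlorophenyl on an amide-type nitrogen. None of these steps leaves the scatter, and three compounds are a thin basis, so the range is kept wide.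

The expected result is a 1.1-fold lower number from compound 3 to compound 4 (0.05 log units; within the scatter) and no shift beyond the scatter is expected in either direction. In this assay compound 4 is estimated at 700 nM with an expected range from 350 nM to 1300 nM for repeated measurements.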

Compound 4, concentration for 50% growth inhibition: 3860 nM
For compound 4 the middle estimate is 5.5-fold (0.74 log units) below the measured one, outside the stated range (above it).
By their numbers in this assay, from the lowest: compounds 2, 3 and 1 (each within the scatter of the next); then compound 4.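

In this assay, within the data shown here, the arrangement of the two chlorines on the aromatic ring at the amide-type nitrogen makes a difference that the earlier compounds, all within the scatter of one another, gave no sign of: with the same atoms joined differently, 3,4-dichlorophenyl in place of 3,5-dichlorophenyl gives a 4.9-fold higher number from compound 3 to compound 4 (0.69 log units; beyond the scatter). The weaker inhibition of growth also holds against each chlorophenyl compound, with a 6.0-fold higher number from compound 2 to compound 4 (0.78 log units; beyond the scatter) and a 4.2-fold higher number from compound 1 to compound 4 (0.63 log units; beyond the scatter). Adding a chloro at this position is therefore not a change of fixed size, and its outcome depends on the chlorophenyl group that receives it: the same change on two cores in this assay, a 1.2-fold lower number (0.07 log units; within the scatter) from compound 1 to compound 3 and a 6.0-fold higher number (0.78 log units; beyond the scatter) from compound 2 to compound 4, 7.0-fold (0.85 log units) apart, beyond the scatter of two such steps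

The compounds shown carry only chloro groups on this aromatic ring, so it stays open whether methyl, methoxy or trifluoromethyl in place of chloro would follow compound 4 or stay with the other three. On these data alone, it also stays open whether the gap between 3,4-dichlorophenyl and 3,5-dichlorophenyl would recur with a plain benzyl group in place of the methoxybenzyl group on the shared core.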